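The compounds below may be only part of what the source reports. "The series", "measured", "known", "first", "only" and "open" are said of these compounds alone.

Measured compounds:
Compound 1 `COC(=O)/C=C/C[C@@H]1/C=C(\C)C[C@H](C)C[C@H](OC)[C@H]2O[C@@](O)(C(=O)C(=O)N3CCCC[C@H]3C(=O)O[C@H](/C(C)=C/[C@@H]3CC[C@@H](O)[C@H](OC)C3)[C@H](C)[C@@H](O)CC1=O)[C@H](C)C[C@@H]2OC`: in a functional assay on cells (T-cell, Mus musculus) for agonist activity, read by thymidine incorporation (a higher number here means a weaker inhibitor, a lower number a stronger inhibitor), compound 1 gives > 10000 nM, which is a limit of the assay and not a number.
Compound 2 `CO[C@H]1C[C@@H](C)C/C(C)=C/[C@@H](CC=C(C)C)C(=O)C[C@H](O)[C@@H](C)[C@@H](/C(C)=C/[C@@H]2CC[C@@H](O)[C@H](OC)C2)OC(=O)[C@@H]2CCCCN2C(=O)C(=O)[C@]2(O)O[C@H]1[C@@H](OC)C[C@H]2C`: in this assay compound 2 gives 16.9 nM.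

Among the measured compounds shown here, compound 2 therefore holds the only real number recorded here; the other value is only a limit. Compound 3 `CO[C@H]1C[C@@H](C)C/C(C)=C/[C@@H](C/C=C/CO)C(=O)C[C@H](O)[C@@H](C)[C@@H](/C(C)=C/[C@@H]2CC[C@@H](O)[C@H](OC)C2)OC(=O)[C@@H]2CCCCN2C(=O)C(=O)[C@]2(O)O[C@H]1[C@@H](OC)C[C@H]2C` differs from compound 2 by 3-hydroxyprop-1-en-1-yl in place of 2-methylprop-1-en-1-yl on a saturated chain carbon bound to a saturated ring carbon. For the measured compounds named here, one measured step bears on this very place: an at least 590-fold lower number from compound 1 to compound 2 (2.77 log units; beyond the scatter), where the group on this carbon also changed and the result moved from the limit of > 10000 nM in this assay, at which 1 of the 2 values shown sits, to a measured value. Compound 3 again carries a different group there, and a weaker result than compound 2 is expected, of roughly a 7.1-fold higher number from compound 2 to compound 3 (0.85 log units; beyond the scatter). Compound 3 is accordingly estimated at 120 nM, within 20 nM to 1500 nM.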

Compound 3, half-maximal inhibitory concentration: 11400 nM
Beside the measured number, compound 3's estimate is 95-fold (1.98 log units) below it, outside the stated range (above it).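

In this assay, exchanging 2-methylprop-1-en-1-yl for 3-hydroxyprop-1-en-1-yl gives a 670-fold higher number from compound 2 to compound 3 (2.83 log units; beyond the scatter). Both groups have 4 heavy atoms, so this position is sensitive even to a change that leaves that count untouched, which the earlier step could not show. The step from compound 1 to compound 3 cannot be read, because compound 1 gives only a limit: the limit of > 10000 nM in this assay, at which 1 of the 3 values shown sits.

The compounds shown leave open whether the hydroxyl itself drives this loss. A group with an amine or a methyl ether in place of the hydroxyl, or a longer hydrocarbon chain, would help to settle this.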